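The source may hold more compounds than are shown below. What is called first, only, known or untested is meant among the compounds shown, and "the series" means these compounds.

Of the compounds shown here, three built on one shared core have been tested in an ADME assay on WI-38 cells (Homo sapiens) for cytotoxicity, read by MTT assay, with a stated time of 72 h; a lower number here means a stronger inhibitor, a higher number a weaker inhibitor. Compound 1 `O=C(CCc1cccc2c1B(O)OC2)Nc1nccs1` reaches only a limit of the assay, > 100000 nM, so no number is known for it. Compound 2 `CC(C)(C)c1ccc(NC(=O)CCc2cccc3c2B(O)OC3)cc1` gives 55000 nM in this assay. Compound 3 `CC(C)c1cccc(NC(=O)CCc2cccc3c2B(O)OC3)c1` gives 22000 nM in this assay, the lowest of the two numbers; the value of compound 2 sits above it by more than the usual scatter. For the measured compounds named here, no two of the measured compounds differ in a single place, so no single step has been measured so far.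

Compound 4 `N#Cc1ccc(-c2cccc(NC(=O)CCc3cccc4c3B(O)OC4)c2)cc1` is not yet measured. It differs from compound 3 in one place: 4-cyanophenyl in place of isopropyl on an aromatic carbon. Both measured numbers come from compounds carrying a substituted phenyl on the amide, and that is all the data say about this region. The step from compound 3 to compound 4 in this assay is expected to be a 1.5-fold lower number from compound 3 to compound 4 (0.17 log units; within the scatter), a modest move toward a lower number at most. Compound 4 is therefore estimated at 15000 nM, within a range from 5000 nM to 50000 nM.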

Compound 4, half-maximal inhibitory concentration: 12000 nM
Beside the measured number, compound 4's estimate is 1.3-fold (0.10 log units) above it; low and high end bracket the measured number.
By their numbers in this assay, from the lowest: compounds 4 and 3 (each within the scatter of the next); then compound 2. At a limit, above all of these: compound 1.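

In this assay, for the compounds shown here, the first step between two compounds that differ in one place is a 1.8-fold lower number from compound 3 to compound 4 (0.26 log units; within the scatter), and it gives this series its first direct reading of a single change. On an aromatic carbon meta to a large group, 4-cyanophenyl, with 8 heavy atoms and a six-membered aromatic ring, stands in place of isopropyl, with 3 heavy atoms and no ring, and the two compounds still read the same within the scatter. So at this position, a much larger group with a nitrile at its end does not separate from a small alkyl group in this cell assay. Nothing measured here says why the two groups read alike.

Still open, on these data alone, is whether an amine or a carboxylic acid at this same position would give a number beyond the scatter from compound 3. Also open, as far as these compounds go, is whether a simple unsubstituted phenyl would read like 4-cyanophenyl.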